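The compounds below may be only part of what the source reports. "The series", "measured", "known", "first", "only" and "open" are said of these compounds alone.

Measured compounds:
- compound 1, `O=C1CCC2(c3ccccc3)OCCCN12`: 37.5 mg/kg
- compound 2, `O=C1CCC2(c3ccc(Cl)cc3)OCCCN12`: 75 mg/kg
- compound 3, `O=C(CCC(=O)c1ccc(Cl)c(Cl)c1)NCCCO`: 300 mg/kg

These values come from a functional assay on the whole organism (Central nervous system) for activation, with Mus musculus as the target; a higher number here means that more compound is needed for the effect, a lower number that less compound is needed. Compound 2 and compound 1 differ by hydrogen in place of chloro on an aromatic carbon, and in this assay the step is a 2.0-fold lower number from compound 2 to compound 1 (0.30 log units; within the scatter). Compound 3 stands on a different core from compound 2; how the two cores differ is not broken down here. Compound 4, `O=C(CCC(=O)c1ccc(Cl)cc1)NCCCO`, has not yet been measured. It differs from compound 3 by hydrogen in place of chloro on an aromatic carbon, the same kind of change as from compound 2 to compound 1, though not the same: in compound 2 the chloro that leaves is para to a large group, while in compound 3 it is ortho to a chloro group and meta to a large group. Because the earlier step was a 2.0-fold lower number from compound 2 to compound 1 (0.30 log units; within the scatter), a step of similar size is expected from compound 3 to compound 4, a 1.5-fold lower number from compound 3 to compound 4 (0.18 log units; within the scatter). For compound 4 the estimate is 200 mg/kg, between 100 mg/kg and 400 mg/kg.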

Compound 4, dose for half-maximal effect: 300 mg/kg
Beside the measured number, compound 4's estimate is 1.5-fold (0.18 log units) below it, and the stated range covers the measured number.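

Putting hydrogen in place of chloro on the aromatic ring gives no change at the digits printed from compound 3 to compound 4 (within the scatter) in this assay. Set beside the same kind of change on the other core, the two steps do not differ by more than the measurements can resolve: the same change on two cores in this assay, a 2.0-fold lower number (0.30 log units; within the scatter) from compound 2 to compound 1 and no change at the digits printed (within the scatter) from compound 3 to compound 4, 2.0-fold (0.30 log units) apart, within the scatter of two such steps

So the change carries across these two cores without a detectable difference, but both steps lie within the scatter, and two cases, with the chloro leaving from different places on the ring, do not show that the cores respond alike. The compounds shown leave open whether a different group on the aromatic ring, such as a methoxy group or an amine, would give a step beyond the scatter.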